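A few compounds are considered here, and "the series" means these few. Any claim that something is new, unique, unknown or untested is made for them only; others in the source may bear on it.

Measured compounds in an ADME assay on microsomes from liver (Homo sapiens) for metabolic stability, read by LC-MS, using NADPH, with stated times of 5 min and 30 min, tested at 1 uM; on this read-out lower numbers stand for slow clearance and higher numbers for fast clearance:
- compound 1, `Cc1nccn1-c1cnc(NCc2c(F)ccc3c2CCO3)c2cn[nH]c(=O)c12`: 8 mL.min-1.g-1
- compound 2, `Cc1nc(CN(C)C)ccc1-c1cnc(NCc2c(F)ccc3c2CCO3)c2cn[nH]c(=O)c12`: 13 mL.min-1.g-1
- compound 3, `CC1(C)CC(=O)N(c2cnc(NCc3c(F)ccc4c3CCO4)n3cnnc23)C1`: 16 mL.min-1.g-1

All three numbers sit close together. Compound 3 is not separated from compound 2 or from compound 1 beyond the scatter, so on this read-out the three compounds are indistinguishable. Within the data shown here, the one single-point step, a 1.6-fold higher number from compound 1 to compound 2 (0.21 log units; within the scatter), is itself within the scatter and concerns a different position and different groups from the change now considered.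

Compound 4, `COCCC(=O)Nc1cnc(NCc2c(F)ccc3c2CCO3)n2cnnc12`, differs from compound 3 by ((2-methoxyethyl)carbonyl)amino in place of 4,4-dimethyl-2-oxopyrrolidin-1-yl on an aromatic carbon. Among the measured compounds shown here, no measured pair among compounds 1 to 3 shows this exchange or anything like it, so there is no step to lean on; the only guide is that every number so far lies in the same narrow band. The expectation is therefore no step beyond the scatter, no change at the digits printed from compound 3 to compound 4 (within the scatter), with the usual uncertainty on either side. Compound 4 is estimated at 16 mL.min-1.g-1, in the range 6 mL.min-1.g-1 to 40 mL.min-1.g-1.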

Compound 4, intrinsic clearance in microsomes: < 3 mL.min-1.g-1
Compound 4: only a limit was reported; the forecaster's own chance of this, stated with the estimate: 5%; middle value at least 5.3-fold (0.72 log units) from the limit.
By their numbers in this assay, from the lowest: compounds 1, 2 and 3 (each within the scatter of the next). At a limit, below all of these: compound 4.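

In this assay, this position, on an aromatic carbon of a six-membered aromatic ring with 2 nitrogen, holds the only single exchange shown that moves the number beyond the scatter: ((2-methoxyethyl)carbonyl)amino in place of 4,4-dimethyl-2-oxopyrrolidin-1-yl gives an at least 5.3-fold lower number from compound 3 to compound 4 (0.72 log units; beyond the scatter). The exchange swaps a five-membered non-aromatic ring with 0 hydrogen-bond donors for an open chain with 1 hydrogen-bond donor, and the data do not separate these two differences. The number for compound 4 is a limit of the assay and not a measured value, so the step is a bound: the limit of < 3 mL.min-1.g-1 in this assay, at which 1 of the 4 values shown sits.

Still open, going by these compounds, is how an acetylamino group, a primary amine or a longer ether chain would read at this position in this assay. Also open, on these data alone, is whether ((2-methoxyethyl)carbonyl)amino gives a similar step on the core of compound 1.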